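A few compounds are considered here, and "the series" means these few. Any claim that something is new, unique, unknown or untested is made for them only; others in the source may bear on it.

This account follows a single change made to compound 1 `O=C(Nc1ccc(Oc2ccnc3[nH]ccc23)c(F)c1)c1cc2cccnc2n(-c2ccc(F)cc2)c1=O`. For the measured compounds named here, in a functional assay on NCI-H460 cells (Homo sapiens) for antiproliferative activity, read by MTT assay, with a stated time of 72 h (on this read-out higher numbers stand for weaker inhibition and lower numbers for stronger inhibition), compound 1 gives 87 nM, and it is the only compound here with a number, since compound 2 `COc1ccc(-n2c(=O)c(C(=O)Nc3ccc(Oc4ccnc5[nH]ccc45)c(F)c3)cc3cccnc32)cc1` has no result in this assay ("not determined" (no result reported)). Compound 3 `Cn1ccc2c(Oc3ccc(NC(=O)c4cc5cccnc5n(-c5ccc(F)cc5)c4=O)cc3F)ccnc21` is the unmeasured partner; it carries methyl in place of hydrogen on an aromatic nitrogen, that is, methyl in place of hydrogen on an aromatic nitrogen of a five-membered aromatic ring with one nitrogen, part of a fused system of two rings. No step between two measured compounds is shown, so the size of this change rests on expectation alone. Compound 3 is expected to come out weaker than its parent, a step of a 4.0-fold higher number from compound 1 to compound 3 (0.60 log units; beyond the scatter) that would lie beyond the usual scatter. Compound 3 is therefore estimated at 350 nM in this assay, with a range from 100 nM to 2000 nM.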

Compound 3, half-maximal inhibitory concentration: 250 nM
For compound 3 the middle estimate is 1.4-fold (0.15 log units) above the measured one; measured number inside the range.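

In this assay, this change now has a measured size: methyl in place of hydrogen on an aromatic nitrogen of the five-membered aromatic ring gives a 2.9-fold higher number from compound 1 to compound 3 (0.46 log units; beyond the scatter). The effect is modest, and compound 3 still shows antiproliferative activity at 250 nM, so in this pair activity does not depend on keeping the hydrogen at this position. Nothing available here explains why the number rises.

With a single replacement at this nitrogen, the compounds shown cannot separate the loss of the hydrogen from the presence of the methyl. Going by these compounds, whether an ethyl group, or a longer chain ending in an amine, would be tolerated at this position, and whether the step would grow with the size of the group, remains open.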